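Swapping an oxime-like arm for hydroxymethyl on the core

The source may report more compounds than this note shows. Statements on the series, on what has been measured and on what is new or still open speak of the compounds shown alone.

Measured compounds:
compound 1, `COc1ccc(-n2cc(CO)nn2)cc1`, 341 nM
compound 2, `CCCCCCCCCC(=O)OCc1cn(-c2ccc(Cl)cc2)nn1`, 103 nM
compound 3, `O/N=C/c1cnn(-c2ccccc2)n1`, 457 nM

All three were tested in an assay on isolated protein (strain Swiss) for antagonist activity at P2X purinoceptor 7 (Mus musculus), read by patch clamp, with a stated time of 5 min; on this read-out higher numbers stand for weaker inhibition and lower numbers for stronger inhibition. Compound 3 has the highest number of the three. Compound 1 sits nearest to it, a small gap that stays inside the scatter, so the two cannot be told apart. Compound 2 is furthest, with a clearly lower number, beyond the scatter.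

The next compound, compound 4, `OCc1cnn(-c2ccccc2)n1`, has not yet been measured. It differs from compound 3 in one place: a group of 2 heavy atoms (1 carbon, 1 oxygen; no ring) in place of a group of 3 heavy atoms (1 carbon, 1 nitrogen, 1 oxygen; no ring), on an aromatic carbon. Compound 1 also carries hydroxymethyl on its core and gives 341 nM, a number close to that of compound 3. On this basis, compound 4 is expected to stay close to compound 3, with a step of a 1.1-fold lower number from compound 3 to compound 4 (0.06 log units; within the scatter), not beyond the scatter in either direction. The estimate for compound 4 is 400 nM, with a range from 150 nM to 1200 nM.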

Compound 4, half-maximal inhibitory concentration: 81 nM
Compound 4: the middle estimate sits 4.9-fold (0.69 log units) above what was measured; measured number below the stated range.
By their numbers in this assay, from the lowest: compounds 4 and 2 (each within the scatter of the next); then compounds 1 and 3 (each within the scatter of the next).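

In this assay replacing the group of 3 heavy atoms with hydroxymethyl on this aromatic carbon gives a 5.6-fold lower number from compound 3 to compound 4 (0.75 log units; beyond the scatter) and so moves the number beyond the scatter. For the compounds shown here, this is the first pair that differs in only one place, and it shows that this position responds to a small change in the arm. Both groups carry a hydrogen-bond donor, so keeping that count does not keep the number, and no measurement shown explains the difference.

As far as these compounds go, it remains open whether aminomethyl, a carboxylic acid or a longer chain such as hydroxyethyl on this same carbon would give a lower or higher number than hydroxymethyl. The compounds also leave open whether the same swap would produce a step of similar size on the core of compound 1.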